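The source may hold more compounds than are shown below. What is called first, only, known or untested is meant among the compounds shown, and "the series" means these compounds.

Measured in a functional assay on the whole organism (artery, strain albino) with Rattus norvegicus as the target, with a stated time of 900 min, at a dose of 10 mg/kg by the oral route; on this read-out higher numbers stand for more inhibition at the one dose given (going by the name of the read-out) and lower numbers for less inhibition:
compound 1, `COc1ccc(C2N=C(SCc3ccc(F)cc3)NC(C)=C2C(=O)Nc2ccc(F)cc2)cc1OC`: 15.4%
compound 2, `CC1=C(C(=O)Nc2ccc(F)cc2)C(c2ccc([N+](=O)[O-])cc2)N=C(SCc2ccccc2)N1`: 21%
compound 3, `CC1=C(C(=O)Nc2ccc(Br)cc2)C(c2ccc(Cl)cc2Cl)N=C(SCc2ccccc2)N1`: 8.2%

Of the compounds shown here, three have numbers so far, all at the one oral dose. Compound 3 sits at the bottom of the three numbers, though compound 1 lies within the usual scatter of it and the two cannot be told apart on this evidence. Only compound 2 stands beyond the scatter above compound 3, and with no single-point difference between any of these three, nothing can be tied to a given group.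

Compound 4, `CC1=C(C(=O)Nc2ccc(Br)cc2)C(c2ccc(Cl)cc2Cl)N=C(SCc2ccccc2Cl)N1`, is not yet measured. It differs from compound 3 in one place: chloro in place of hydrogen on an aromatic carbon

Going by the values given here, no measured pair shows what this change does. The three measured compounds differ from one another in several places at once, so they give no direction for it. The expected step of a number 1.8 percentage points higher from compound 3 to compound 4 (within the scatter) is therefore small, with no reason to place it beyond the scatter in either direction. Compound 4 is estimated to give about 10%, with a likely range from 1% to 24%.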

Compound 4, a percentage reported as inhibition, in the whole organism at one dose (the size of the read-out at that dose, not a potency): 16.4%
For compound 4 the middle estimate is 6.4 percentage points below the measured one, within the range that was stated.
By their numbers in this assay, from the lowest: compounds 3, 1, 4 and 2 (each within the scatter of the next, the first and the last beyond it).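

In this assay, the change from benzylsulfanyl to (2-chlorobenzyl)sulfanyl gives the series its first comparison in one place, and it reads a number 8.2 percentage points higher from compound 3 to compound 4 (within the scatter) on the shared core. Compound 3 and compound 4 therefore cannot be told apart at this single oral dose: chloro in place of hydrogen at this position, on an aromatic carbon ortho to a large group, shows neither a gain nor a loss beyond the scatter. No measurement is at hand that would account for the two numbers.

On these data alone, whether an amine, a carboxylic acid or a trifluoromethyl at this same position would carry the number beyond the scatter remains open, as does the outcome for chloro on the other aromatic carbons of this ring. Also open, as far as these compounds go, is whether this change reads the same with the other groups carried by compound 1 and compound 2, since this one step rests on a single pair at a single dose.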